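From Cyclobutyl to 4-Methoxyphenyl: One Untested Step

This account rests on a few compounds, and the source may have more. Where it says the series, first, only, none or still open, it means among the compounds named here.

compound 1 `CCCCc1cnc(Cc2ccc(-c3ccccc3C(=O)O)cc2)[nH]1`: > 10000 nM
compound 2 `O=C(O)c1ccccc1-c1ccc(CCc2ncc(CC3CCC3)[nH]2)cc1`: 588 nM

Of the compounds shown here, two have been measured in an in vitro functional assay on cells for agonist activity at Bombesin receptor subtype-3 (Homo sapiens), read by luminescence and calcium flux; on this read-out lower numbers stand for an effect already at smaller amounts and higher numbers for an effect only at larger amounts of compound. Compound 1 reaches only a limit of the assay, > 10000 nM, and no number. Within the data shown here, compound 2 is the only compound with a number here, giving 588 nM. Among the measured compounds shown here, the one other value shown, that of compound 1, is a limit, as the limit of > 10000 nM in this assay, at which 1 of the 2 values shown sits, records. For the measured compounds named here, because the two compounds differ in more than one place, no single-change step between measured compounds is available.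

Compound 3 `COc1ccc(Cc2cnc(CCc3ccc(-c4ccccc4C(=O)O)cc3)[nH]2)cc1` differs from compound 2 by 4-methoxyphenyl in place of cyclobutyl on a saturated chain carbon bound to an aromatic carbon. With nothing measured to lean on, the step of a 1.3-fold lower number from compound 2 to compound 3 (0.12 log units; within the scatter) is expected to stay within the usual scatter or only a little beyond it, in no firm direction. On that basis compound 3 is estimated at 450 nM, with a range from 100 nM to 3000 nM.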

Compound 3, half-maximal effective concentration: 5360 nM
Estimate against measurement, compound 3: 12-fold (1.08 log units) below, and the stated range ends below it.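

In this assay, the saturated chain carbon bound to an aromatic carbon proves sensitive to the group it carries: 4-methoxyphenyl in place of cyclobutyl gives a 9.1-fold higher number from compound 2 to compound 3 (0.96 log units; beyond the scatter). Among these compounds, this is the first single-change step, and it shows that the exchange weakens the effect without abolishing it, as compound 3 still gives a number and not a limit. Nothing shown accounts for the size of this step.

The compounds shown leave open which part of the exchange matters, as ring size, the aromatic ring and the methoxy group all change together. On these data alone, whether a plain phenyl or a cyclohexyl at this place would stay near compound 2 or fall near compound 3 also remains open.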